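From methyl to dimethylamino in a cytotoxic series

The compounds below may be only part of what the source reports. "The series", "measured", "known", "first", "only" and "open" are said of these compounds alone.

In a functional assay on QG-56 cells (Homo sapiens) for cytotoxicity, read by MTT assay, with a stated time of 48 h (a higher number here means a weaker inhibitor, a lower number a stronger inhibitor), compound 1 (`COc1cc(/C=C/C(=O)C2=C(/C=C/c3ccc(O)c(OC)c3)NC(=O)NC2c2c(Cl)cccc2Cl)ccc1O`) reads 100000 nM and compound 2 (`COc1cc(/C=C/C(=O)C2=C(/C=C/c3ccc(O)c(OC)c3)NC(=O)NC2c2cccc([N+](=O)[O-])c2)ccc1O`) reads 25000 nM on the same scale. Compound 3 (`COc1cc(/C=C/C(=O)C2=C(/C=C/c3ccc(O)c(OC)c3)NC(=S)NC2c2ccc(C)cc2)ccc1O`) reads 12500 nM and so lies within the scatter of compound 2 and clearly apart from compound 1.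

Compound 4 (`COc1cc(/C=C/C(=O)C2=C(/C=C/c3ccc(O)c(OC)c3)NC(=S)NC2c2ccc(N(C)C)cc2)ccc1O`) differs from compound 3 in one place, with dimethylamino in place of methyl on an aromatic carbon, para to a large group (dimethylamino in place of methyl on an aromatic carbon).

Going by the values given here, only one measured step bears on this, and only loosely: a 4.0-fold lower number from compound 1 to compound 2 (0.60 log units; beyond the scatter) is a modest move beyond the scatter. It shows that changing an aromatic group can shift the number, but it involves neither methyl nor dimethylamino. Among the compounds with values here, no measured compound carries dimethylamino, so the data point in no direction, and no step beyond the scatter is expected. The expected outcome is no change at the digits printed from compound 3 to compound 4 (within the scatter) on this evidence. In this assay the estimate for compound 4 is 12500 nM (expected range 5000 nM to 35000 nM).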

Compound 4, half-maximal inhibitory concentration: 25000 nM
The estimate for compound 4 lay 2.0-fold (0.30 log units) below the measured number; the range from low to high includes it.
By their numbers in this assay, from the lowest: compounds 3, 2 and 4 (each within the scatter of the next); then compound 1.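

In this assay, replacing methyl with dimethylamino on an aromatic carbon, para to a large group, gives a 2.0-fold higher number from compound 3 to compound 4 (0.30 log units; within the scatter) and so does not separate the two groups. Going by these compounds alone, this is the first measured change at this position, and it shows that the 4-methylphenyl and 4-(dimethylamino)phenyl compounds read alike here, even though the entering group brings a nitrogen and a hydrogen-bond acceptor that methyl lacks. No supporting measurement offers any explanation for this result.

The compounds shown leave open whether a carboxylic acid, a primary amine or a longer chain at this same place would read differently from methyl. They also leave open whether the same change would read alike in a compound with the carbonyl of compound 1 instead of the thiocarbonyl of compound 3.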